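Hydroxypiperidine in Place of Pyrrolidine: Expected Lipophilicity

This account rests on a few compounds, and the source may have more. Where it says the series, first, only, none or still open, it means among the compounds named here.

Of the three measured compounds, compound 3 `O=C(Nc1ccnnc1)c1cc(N2CCCC2)ccc1OCc1ccccc1` stands second highest in a physicochemical assay for lipophilicity, at pH 7.4; on this read-out lower numbers stand for lower lipophilicity and higher numbers for higher lipophilicity; compound 3 gives 6.1. Compound 2 `O=C(Nc1ccnnc1)c1cc(N2CCC(F)CC2)ccc1OCc1ccccc1` is nearest, and compound 2 gives 5.1; compound 1 `N#Cc1cccc(NC(=O)c2cc(C(F)(F)F)ccc2OCc2ccc(F)cc2)c1` lies furthest away, and compound 1 gives 7.5. Compound 4 `O=C(Nc1ccnnc1)c1cc(N2CCC(O)CC2)ccc1OCc1ccccc1` differs from compound 3 in one place: 4-hydroxypiperidin-1-yl in place of pyrrolidin-1-yl on an aromatic carbon. Among the compounds with values here, the single measured step that bears on this change is a number 1.00 log units higher from compound 2 to compound 3 (beyond the scatter), which set pyrrolidin-1-yl against 4-fluoropiperidin-1-yl. Read in reverse, with a hydroxyl where the fluorine stood, the exchange is expected to lower the number beyond the scatter, and the expected step is a number 1.50 log units lower from compound 3 to compound 4 (beyond the scatter). Compound 4 is therefore estimated at 4.6, within 3.9 to 5.3.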

Compound 4, distribution coefficient: 3.2
For compound 4 the middle estimate is 1.40 log units above the measured one, and the stated range ends above it.
By their numbers in this assay, from the lowest: compound 4; then compound 2; then compound 3; then compound 1.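

At this position, on the aromatic carbon para to the benzyloxy group, this assay shows a large move with 4-hydroxypiperidin-1-yl in place of pyrrolidin-1-yl: a number 2.90 log units lower from compound 3 to compound 4 (beyond the scatter). Within the data shown here, with the six-membered ring kept, hydroxy in place of fluoro on the saturated ring carbon also gives a large step, a number 1.90 log units lower from compound 2 to compound 4 (beyond the scatter), which the earlier compounds did not show. Nothing measured here explains either step.

Unsubstituted piperidin-1-yl does not appear among these compounds, so ring size and the ring substituent remain unseparated in the exchange of pyrrolidin-1-yl. As far as these compounds go, whether a methoxy group or an amine in place of the hydroxy would give a similar number also remains open.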